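This account rests on a few compounds, and the source may have more. Where it says the series, first, only, none or still open, it means among the compounds named here.

Measured so far: compound 1 `COc1ccc(Cl)cc1S(=O)(=O)Nc1ccc(-c2nc3ccccc3o2)cc1`, > 100000 nM; compound 2 `O=S(=O)(Nc1ccc2oc(-c3ccccc3)nc2c1)c1ccccc1Cl`, > 100000 nM.

In an assay on cells for inhibition of HSP60/HSP10 (Homo sapiens), with a stated time of 60 min (a higher number here means a weaker inhibitor, a lower number a stronger inhibitor), compound 1 gives > 100000 nM, which is a limit of the assay and not a number. Compound 2 gives > 100000 nM in this assay, again a limit. Both results sit at the limit of > 100000 nM in this assay, at which 2 of the 2 values shown sit, so compound 1 stands at the weak edge of what has been seen. Compound 3 `O=S(=O)(Nc1ccc(-c2nc3ccccc3o2)cc1)c1ccc(O)cc1` differs from compound 1 by 4-hydroxyphenyl in place of 5-chloro-2-methoxyphenyl on a sulfonyl sulfur. Within the data shown here, no measured step covers this change, and the step expected from compound 1 to compound 3 in this assay is small, about a number no higher from compound 1 to compound 3 (the limit leaves the size open). Compound 3 is therefore expected near 100000 nM, between 20000 nM and 300000 nM.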

Compound 3, half-maximal inhibitory concentration: 78000 nM
For compound 3 the middle estimate is 1.3-fold (0.11 log units) above the measured one; measured number inside the range.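

With 4-hydroxyphenyl in place of 5-chloro-2-methoxyphenyl on a sulfonyl sulfur, this assay gives an at least 1.2-fold lower number from compound 1 to compound 3 (0.10 log units; that floor lies within the scatter). Among these compounds, compound 3 thus gives the first value here that is a number and not a limit, though it remains a weak one at 78000 nM. Compound 1 has only a limit, so the true size of the step stays open: the limit of > 100000 nM in this assay, at which 2 of the 3 values shown sit.

The step swaps the whole aryl group at once, so the hydroxy group cannot be separated from the loss of the chlorine and methoxy groups. As far as these compounds go, whether an amine or a carboxylic acid in place of that hydroxy group would give a lower number than compound 3 also stays open.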